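Aryl replacement on the carbon double-bonded to nitrogen

This account rests on a few compounds, and the source may have more. Where it says the series, first, only, none or still open, it means among the compounds named here.

Compound 3 `Brc1cccc(/C=N/Nc2nc3ccccc3nc2Cc2ccccc2)c1` gives 48000 nM in an assay on isolated protein for inhibition of Amine oxidase [flavin-containing] B (Homo sapiens), read by spectrophotometry (a lower number here means a stronger inhibitor, a higher number a weaker inhibitor), the lowest of the three numbers in hand. Compound 2 `Clc1ccccc1/C=N/Nc1nc2ccccc2nc1Cc1ccccc1` gives 87000 nM in this assay, and its gap to compound 3, a 1.8-fold lower number from compound 2 to compound 3 (0.26 log units; within the scatter), is within the scatter, so no order between these two can be claimed. Compound 1 `COc1ccccc1/C=N/Nc1nc2ccccc2nc1Cc1ccccc1` gives 790000 nM in this assay; the steps of a 9.1-fold lower number from compound 1 to compound 2 (0.96 log units; beyond the scatter) and a 16-fold lower number from compound 1 to compound 3 (1.22 log units; beyond the scatter) are both beyond the scatter.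

Compound 4 `Cc1ccsc1/C=N/Nc1nc2ccccc2nc1Cc1ccccc1` differs from compound 3 in one place: 3-methylthiophen-2-yl in place of 3-bromophenyl on a carbon with a double bond to nitrogen. Within the data shown here, two measured steps touch the same position. a 16-fold lower number from compound 1 to compound 3 (1.22 log units; beyond the scatter) is large, while a 1.8-fold lower number from compound 2 to compound 3 (0.26 log units; within the scatter) stays within the scatter; both exchange one six-membered aromatic ring of carbon only for another, whereas compound 4 brings in a five-membered aromatic ring with one hetero atom and one hydrogen-bond acceptor, for which no measured step exists. The measured range at this position runs from no change to a large one, and the direction for a ring of a different kind is not fixed by the data. A modest step, a 1.7-fold higher number from compound 3 to compound 4 (0.22 log units; within the scatter), toward a higher number is therefore expected in this assay, with wide bounds. Compound 4 is estimated at 80000 nM, in the range 25000 nM to 250000 nM.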

Compound 4, half-maximal inhibitory concentration: 860000 nM
Compound 4: the middle estimate sits 11-fold (1.03 log units) below what was measured; the measured number lies above the stated range.
By their numbers in this assay, from the lowest: compounds 3 and 2 (each within the scatter of the next); then compounds 1 and 4 (each within the scatter of the next).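

The five-membered ring does not behave like the two halogen-bearing aryl groups at this position: 3-methylthiophen-2-yl costs heavily against 3-bromophenyl (an 18-fold higher number from compound 3 to compound 4 (1.25 log units; beyond the scatter)) and clearly against 2-chlorophenyl (a 9.9-fold higher number from compound 2 to compound 4 (0.99 log units; beyond the scatter)). Against 2-methoxyphenyl it brings no readable change (a 1.1-fold higher number from compound 1 to compound 4 (0.04 log units; within the scatter)), so the four aryl groups now fall into two levels in this assay, with compound 2 and compound 3 at the lower numbers and compound 1 and compound 4 at the higher ones, and among these four compounds only the two carrying a halogen reach the lower level. No measurement shown here accounts for this split between the two levels.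

The compounds shown leave open whether the step to compound 4 comes from the sulfur-containing ring itself or from its methyl group, a question that thiophen-2-yl without the methyl and a plain phenyl would help to settle. Also open, from the compounds shown here alone, is whether a ring with a basic nitrogen such as pyridinyl, or an aryl group bearing an amine or a carboxylic acid, would stay at the higher level or reach the lower one.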